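The source may report more compounds than this note shows. Statements on the series, on what has been measured and on what is new or still open speak of the compounds shown alone.

Measured so far:
Compound 1, `CCCCCC(=O)Nc1ccc(S(=O)(=O)Oc2ccccc2C(C)C)cc1`: 6400 nM
Compound 2, `CCCCCC(=O)Nc1ccc(S(=O)(=O)Oc2ccccc2I)cc1`: 13000 nM
Compound 3, `CCNC(=O)Nc1ccc(S(=O)(=O)Oc2ccccc2C(C)C)cc1`: 1100 nM

All three were tested in a functional assay on HT-29 cells (Homo sapiens) for antiproliferative activity, read by sulforhodamine B assay, with a stated time of 48 h; a higher number here means a weaker inhibitor, a lower number a stronger inhibitor. Compound 1 and compound 2 share a core and differ in one place, (iodo in place of isopropyl on an aromatic carbon), and that change gave a 2.0-fold higher number from compound 1 to compound 2 (0.31 log units; beyond the scatter). Compound 3 keeps the isopropyl group of compound 1 but sits on a different core; the difference between the two cores is ethylamino in place of pentyl on a carbonyl carbon, which gave a 5.8-fold lower number from compound 1 to compound 3 (0.76 log units; beyond the scatter). Compound 4, `CCNC(=O)Nc1ccc(S(=O)(=O)Oc2ccccc2I)cc1`, has not yet been measured. It arises from compound 3 by iodo in place of isopropyl on an aromatic carbon, the same change that turned compound 1 into compound 2, at the same kind of place. Because that single earlier example gave a 2.0-fold higher number from compound 1 to compound 2 (0.31 log units; beyond the scatter), the expected step is a 2.0-fold higher number from compound 3 to compound 4 (0.30 log units; within the scatter), about the same size, although one example is a thin basis. Compound 4 is therefore estimated at 2200 nM, with a likely range from 1100 nM to 4500 nM.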

Compound 4, half-maximal inhibitory concentration: 5300 nM
For compound 4 the middle estimate is 2.4-fold (0.38 log units) below the measured one; the whole stated range lies below it.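

In this assay, iodo in place of isopropyl on an aromatic carbon again raised the number, with a 4.8-fold higher number from compound 3 to compound 4 (0.68 log units; beyond the scatter), so the two cores agree in direction and, allowing for scatter, in size: the same change on two cores in this assay, a 2.0-fold higher number (0.31 log units; beyond the scatter) from compound 1 to compound 2 and a 4.8-fold higher number (0.68 log units; beyond the scatter) from compound 3 to compound 4, 2.4-fold (0.38 log units) apart, within the scatter of two such steps. Ethylamino in place of pentyl on a carbonyl carbon also behaved alike on both cores, with a 2.5-fold lower number from compound 2 to compound 4 (0.39 log units; beyond the scatter), and these steps likewise agree: the same change on two cores in this assay, a 5.8-fold lower number (0.76 log units; beyond the scatter) from compound 1 to compound 3 and a 2.5-fold lower number (0.39 log units; beyond the scatter) from compound 2 to compound 4, 2.4-fold (0.38 log units) apart, within the scatter of two such steps. Going by these compounds alone, each change therefore carried over here, but this rests on only two pairs of compounds in one cell assay and does not show that it would hold on other cores or explain why it occurs.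

As far as these compounds go, it remains open how a bromo or methoxy group would behave on that aromatic carbon. From the compounds shown here alone, the effect of methylamino or propylamino on the carbonyl carbon also remains open.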